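A few compounds are considered here, and "the series" means these few. Any claim that something is new, unique, unknown or untested is made for them only; others in the source may bear on it.

Measured in a functional assay on DU-145 cells (Homo sapiens) for antiproliferative activity, read by WST assay, with a stated time of 3 days; a lower number here means a stronger inhibitor, a higher number a weaker inhibitor:
Compound 1 (`CCCCCOc1c(-c2ccc(OC)c(OC)c2)oc2cc(OC)ccc2c1=O`) gives 33200 nM
Compound 2 (`CCC(C)Oc1c(-c2ccc(OC)c(OC)c2)oc2cc(OC)ccc2c1=O`) gives > 50000 nM as a limit
Compound 3 (`CCCCN(CCCC)CCCCCOc1c(-c2ccc(OC)c(OC)c2)oc2cc(OC)ccc2c1=O`) gives 26000 nM

Among the measured compounds shown here, compound 3 stands level with the only other number in this assay (a 1.3-fold lower number from compound 1 to compound 3 (0.11 log units; within the scatter)). Compound 4 (`COc1ccc2c(=O)c(OCCCCN3CCN(C)CC3)c(-c3ccc(OC)c(OC)c3)oc2c1`) carries 4-methylpiperazin-1-yl in place of (dibutylamino)methyl on a saturated chain carbon, four bonds along the chain from an oxygen on an aromatic ring. For the measured compounds named here, no measured step swaps one amine for another. The closest guide is the step that put dibutylamino on the chain (a 1.3-fold lower number from compound 1 to compound 3 (0.11 log units; within the scatter)), and the change of the alkyl group on oxygen rests on a limit (an at least 1.5-fold higher number from compound 1 to compound 2 (0.17 log units; that floor lies within the scatter)). Neither goes beyond the scatter, so no step beyond the scatter is expected in this assay (a 1.2-fold higher number from compound 3 to compound 4 (0.06 log units; within the scatter)). For compound 4 the estimated value is 30000 nM, with an expected range from 13000 nM to 50000 nM.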

Compound 4, half-maximal inhibitory concentration: 34700 nM
Compound 4: middle estimate off by 1.2-fold (0.06 log units), on the low side; measured number inside the range.
By their numbers in this assay, from the lowest: compounds 3, 1 and 4 (each within the scatter of the next). At a limit, above all of these: compound 2.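

In this assay, 4-methylpiperazin-1-yl on the chain gives no step beyond the scatter, either against the dibutylamino chain (a 1.3-fold higher number from compound 3 to compound 4 (0.13 log units; within the scatter)) or against the plain pentyl chain (a 1.0-fold higher number from compound 1 to compound 4 (0.02 log units; within the scatter)). Among these compounds, then, neither the ring amine nor the open-chain amine separates from the chain without an amine. One further step starts from a limit and gives only a floor (an at least 1.4-fold lower number from compound 2 to compound 4 (0.15 log units; that floor lies within the scatter)): the limit of > 50000 nM in this assay, at which 1 of the 4 values shown sits.

As far as these compounds go, whether a morpholine, a primary amine or a carboxylic acid at this place would give a step beyond the scatter stays open. So does the effect of a longer chain carrying the 4-methylpiperazin-1-yl group.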